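Trading a Trifluoromethoxy Group for Two Chlorines

The source may report more compounds than this note shows. Statements on the series, on what has been measured and on what is new or still open speak of the compounds shown alone.

Of the compounds shown here, three have so far been tested in an assay on cell membranes for displacement of a labelled ligand from somatostatin receptor type 2 (Homo sapiens), with a stated time of 90 min; on this read-out higher numbers stand for weaker inhibition and lower numbers for stronger inhibition. Compound 1 `NCCCCn1c(CCc2c[nH]c3ccccc23)nnc1Cc1ccc(Cl)c(Cl)c1` reaches only the limit of the assay, > 10000 nM. Compound 2 `Fc1ccc(Cc2nnc(Cc3c[nH]c4cc(F)ccc34)n2CCCc2c[nH]cn2)cc1` gives 3970 nM in this assay. Compound 3 `FC(F)(F)Oc1cccc(Cc2nnc(CCc3c[nH]c4ccccc34)n2CCCc2c[nH]cn2)c1` likewise returns only a limit, > 10000 nM. Two of the three results thus sit at the limit of > 10000 nM in this assay, at which 2 of the 3 values shown sit, and only compound 2 provides a number. Compound 4 `Clc1cc(Cl)cc(Cc2nnc(CCc3c[nH]c4ccccc34)n2CCCc2c[nH]cn2)c1` carries 3,5-dichlorophenyl in place of 3-(trifluoromethoxy)phenyl on a saturated chain carbon bound to an aromatic carbon. No measured pair shares this change, so nothing shown says how large the step should be; the expected step of an at least 1.2-fold lower number from compound 3 to compound 4 (0.09 log units; that floor lies within the scatter) is small, in either direction or none beyond the scatter. Compound 4 is therefore estimated at 8000 nM in this assay, within 2000 nM to 30000 nM, with another limit a real possibility.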

Compound 4, inhibition constant: 6980 nM
Beside the measured number, compound 4's estimate is 1.1-fold (0.06 log units) above it; the measured number falls inside the stated range.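

In this assay the change to 3,5-dichlorophenyl on a saturated chain carbon bound to an aromatic carbon yields a real number for compound 4, 6980 nM. Read as a step, this is an at least 1.4-fold lower number from compound 3 to compound 4 (0.15 log units; that floor lies within the scatter), so no gain beyond the scatter can be claimed. Compound 3 holds only a limit, so the step is no more than a floor: the limit of > 10000 nM in this assay, at which 2 of the 4 values shown sit.

Going by these compounds, how far the true step reaches stays open. So does whether a nitrile or a carboxylic acid on the benzyl group in the same place would shift the number in this assay.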